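This account rests on a few compounds, and the source may have more. Where it says the series, first, only, none or still open, it means among the compounds named here.

Measured so far in a functional assay (trachea) with Cavia porcellus as the target; on this read-out lower numbers stand for stronger inhibition and higher numbers for weaker inhibition:
- compound 1 `Cn1nc(-c2cccnc2)c2ccccc2c1=O` gives 11500 nM
- compound 2 `O=c1c2ccccc2c(-c2cccnc2)nn1Cc1cccc(Cl)c1` gives 4170 nM

Of these two numbers, compound 2 holds the lower one. Compound 3 `O=c1c2ccccc2c(-c2cccnc2)nn1CCSc1nccs1` has not been measured. It carries ((1,3-thiazol-2-yl)sulfanyl)methyl in place of the 3-chlorophenyl of compound 2, on a saturated chain carbon bound to an aromatic nitrogen (((1,3-thiazol-2-yl)sulfanyl)methyl in place of 3-chlorophenyl on a saturated chain carbon bound to an aromatic nitrogen). Going by the values given here, only one measured step bears on this place. That step, a 2.8-fold lower number from compound 1 to compound 2 (0.44 log units; beyond the scatter), is modest but beyond the scatter, and it introduced the group that now leaves. Among the compounds with values here, no measured compound carries the entering group, so the direction stays open, and in this assay a small step, perhaps none beyond the scatter, is expected. The estimated step is small (a 1.1-fold higher number from compound 2 to compound 3 (0.03 log units; within the scatter)) and no larger one is expected. Compound 3 is estimated at 4500 nM with a range from 1500 nM to 13000 nM expected for repeat measurements.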

Compound 3, half-maximal inhibitory concentration: 10500 nM
Compound 3: the middle estimate sits 2.3-fold (0.37 log units) below what was measured; low and high end bracket the measured number.
By their numbers in this assay, from the lowest: compound 2; then compounds 3 and 1 (each within the scatter of the next).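

In this assay, the exchange on a saturated chain carbon bound to an aromatic nitrogen is not neutral: 2-((1,3-thiazol-2-yl)sulfanyl)ethyl in place of 3-chlorobenzyl gives (a 2.5-fold higher number from compound 2 to compound 3 (0.40 log units; beyond the scatter)), although both of the exchanged groups hold 7 heavy atoms. The gain seen with 3-chlorobenzyl therefore does not extend to every group of this count, and the comparison with the methyl compound gives (a 1.1-fold lower number from compound 1 to compound 3 (0.04 log units; within the scatter)), which leaves compound 3 within the scatter of compound 1. Nothing at hand explains why the two groups differ.

The compounds shown do not separate the contributions of the thiazole ring, the sulfur and the two-carbon link in this change. They also leave open whether an amine or a carboxylic acid in this place would shift the number in either direction.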